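Phenyl in place of dichlorophenyl: expected cell tolerance

The source may hold more compounds than are shown below. What is called first, only, known or untested is meant among the compounds shown, and "the series" means these compounds.

Compound 1 `CC(CSc1nnc(-c2ccncc2)s1)C(=O)Nc1c(Cl)cccc1Cl` was examined in an ADME assay on HepG2 cells (Homo sapiens) for cytotoxicity, with a stated time of 3 days; a higher number here means that more compound is tolerated, a lower number that less compound is tolerated. In that test compound 1 reaches only the limit of the assay, > 50000 nM, and gives no number. Compound 2 `CC(Sc1nnc(-c2ccncc2)s1)C(=O)Nc1ccc(Cl)cc1` behaves the same way, as in this assay compound 2 also gives only the assay limit, > 50000 nM. Compound 1 therefore stands where every value shown stands, at the limit of > 50000 nM in this assay, at which 2 of the 2 values shown sit. Compound 3 `CC(CSc1nnc(-c2ccncc2)s1)C(=O)Nc1ccccc1` has not yet been measured in this assay. It differs from compound 1 in a single place, (phenyl in place of 2,6-dichlorophenyl on an amide-type nitrogen). Among the compounds with values here, no step between measured compounds exists here, so the expectation rests on the two limits alone. Both measured compounds are tolerated up to the limit, and no step beyond the scatter is anticipated in this assay in either direction. Compound 3 is thus expected to give about 60000 nM, within 30000 nM to 150000 nM. The expected step that the limit leaves unreadable from compound 1 to compound 3 amounts to no change beyond the scatter.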

Compound 3, half-maximal cytotoxic concentration: > 50000 nM
Compound 3 was reported as a limit; the forecaster's own chance of this, stated with the estimate: 80%; the middle value does not contradict the limit.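

Within the data shown here, compound 3, like compound 1, gives only a limit in this assay, so no step from compound 1 to compound 3 can be read: the limit of > 50000 nM in this assay, at which 3 of the 3 values shown sit. The compounds shown leave open where the half-maximal cytotoxic concentration of each lies, and whether phenyl and 2,6-dichlorophenyl differ there.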